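A Third Aryl Variation and Its Expected Cytotoxicity

The source may report more compounds than this note shows. Statements on the series, on what has been measured and on what is new or still open speak of the compounds shown alone.

Measured compounds:
compound 1, `COc1ccc(/C=C/C(=O)Nc2cc(C(=O)c3cc(OC)c(OC)c(OC)c3)ccc2OC)cc1`: 11800 nM
compound 2, `COc1cc(/C=C/C(=O)Nc2cc(C(=O)c3cc(OC)c(OC)c(OC)c3)ccc2OC)ccc1F`: 15500 nM

Both numbers come from a functional assay on ME-180 cells (Homo sapiens) for cytotoxicity, read by MTT assay, with a stated time of 72 h; on this read-out lower numbers stand for stronger inhibition and higher numbers for weaker inhibition. Compound 2 shows the higher of the two values, but the step of a 1.3-fold higher number from compound 1 to compound 2 (0.12 log units; within the scatter) lies within the scatter, so the two compounds cannot be ranked against each other. Compound 3, `COc1ccc(C(=O)c2cc(OC)c(OC)c(OC)c2)cc1NC(=O)/C=C/c1cccc(OC(F)(F)F)c1`, has not yet been measured; it differs from compound 2 by 3-(trifluoromethoxy)phenyl in place of 4-fluoro-3-methoxyphenyl on a double-bonded chain carbon bound to a double-bonded chain carbon. Among the measured compounds shown here, the only measured step that bears on this change is a 1.3-fold higher number from compound 1 to compound 2 (0.12 log units; within the scatter), which also exchanged the aryl group at this same position and stayed within the scatter. A single step of that kind offers no basis for expecting a shift beyond the scatter in this assay in either direction. Compound 3 is therefore expected to give an estimated 14000 nM, ranging from 5000 nM to 40000 nM, which amounts to an expected 1.1-fold lower number from compound 2 to compound 3 (0.04 log units; within the scatter).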

Compound 3, half-maximal inhibitory concentration: 9200 nM
Compound 3: middle estimate off by 1.5-fold (0.18 log units), on the high side; the range from low to high includes it.
By their numbers in this assay, from the lowest: compounds 3, 1 and 2 (each within the scatter of the next).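

In this assay, 3-(trifluoromethoxy)phenyl on a double-bonded chain carbon bound to a double-bonded chain carbon gives a 1.7-fold lower number from compound 2 to compound 3 (0.23 log units; within the scatter) when it replaces 4-fluoro-3-methoxyphenyl and a 1.3-fold lower number from compound 1 to compound 3 (0.11 log units; within the scatter) when it replaces 4-methoxyphenyl, so both new exchanges stay within the scatter, as the first did. Where the earlier compounds offered a single exchange at this place, three aryl groups can now be compared, and in this assay they cannot be ranked against one another. Nothing at hand explains this result.

From the compounds shown here alone, all three compounds carry a substituted phenyl group at this place, so it remains open whether an amine, a carboxylic acid or a pyridine ring there would move the number beyond the scatter. Also open, going by these compounds, is what a longer chain would do in place of the double-bonded chain.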